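Chloro for Methoxy: Expected Cytotoxicity of Compound 3

The source may report more compounds than this note shows. Statements on the series, on what has been measured and on what is new or still open speak of the compounds shown alone.

Compound 1 `CCN(CC)CN1C(=O)/C(=N/NC(=S)Nc2ccc(Cl)cc2)c2ccccc21`: >= 4000 nM
Compound 2 `CCN(CC)CN1C(=O)/C(=N/NC(=S)Nc2ccc(OC)cc2)c2cc(Cl)ccc21`: 4000 nM

Within the data shown here, in an ADME assay on HeLa cells (Homo sapiens) for cytotoxicity (on this read-out higher numbers stand for lower toxicity in this test and lower numbers for higher toxicity in this test), compound 2 gives 4000 nM, the only plain number among the two values shown. For compound 1 the result in this assay is a limit of the test, >= 4000 nM, not a number. Compound 3 `CCN(CC)CN1C(=O)/C(=N/NC(=S)Nc2ccc(Cl)cc2)c2cc(Cl)ccc21` differs from compound 2 by chloro in place of methoxy on an aromatic carbon. Among the measured compounds shown here, no measured pair shows what this change does here, so no shift beyond the usual scatter is expected, and a result reported only as a limit is quite possible. Compound 3 is estimated at 4000 nM, between 2000 nM and 8000 nM. The expected step is no change at the digits printed from compound 2 to compound 3 (within the scatter).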

Compound 3, minimum cytotoxic concentration: 100000 nM
For compound 3 the middle estimate is 25-fold (1.40 log units) below the measured one, outside the stated range (above it).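

In this assay, going from 4-methoxyphenyl to 4-chlorophenyl gives a 25-fold higher number from compound 2 to compound 3 (1.40 log units; beyond the scatter), so the group at this position can matter greatly, with chloro here reading as far less toxic in this test than methoxy. The step from compound 1 to compound 3 cannot be read, because compound 1 gives only a limit: the limit of >= 4000 nM in this assay, at which 1 of the 3 values shown sits.

Going by these compounds, whether this step comes from chloro itself or from the loss of methoxy stays open. How a smaller fluoro, a methyl, an amine or a carboxylic acid at this position would read is also unknown.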